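Oxygen for sulfur in the side ring of compound 1

The source may hold more compounds than are shown below. What is called first, only, known or untested is meant among the compounds shown, and "the series" means these compounds.

Compound 1 `O=S(=O)(CC1=NCCS1)C1C(c2ccccc2)=NN(c2ccccc2)C1c1ccccc1` stands at the bottom of what is known so far: in a functional assay, tested at 50 ug/mL (on this read-out higher numbers stand for a stronger effect at the one concentration tested and lower numbers for a weaker effect), compound 1 gives "not active" (no number reported), so no number is available for it. Compound 2 `O=S(=O)(CC1=NCCS1)C1C(c2ccc(Cl)cc2)=NN(c2ccccc2)C1c1ccc(Cl)cc1`, which carries the same core with two chlorine atoms added, gives in this assay likewise "not active" (no number reported). Compound 3 `O=S(=O)(CC1=NCCO1)c1c(-c2ccccc2)noc1-c1ccccc1` sits on a different core and gives in this assay a value of 57.2%, the only numeric entry of the set.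

Compound 4 `O=S(=O)(CC1=NCCO1)C1C(c2ccccc2)=NN(c2ccccc2)C1c1ccccc1` differs from compound 1 in one place: a group of 5 heavy atoms (3 carbon, 1 nitrogen, 1 oxygen; one five-membered non-aromatic ring with 2 hetero atoms) in place of a group of 5 heavy atoms (3 carbon, 1 nitrogen, 1 sulfur; one five-membered non-aromatic ring with 2 hetero atoms), on a saturated chain carbon bound to a sulfonyl sulfur. Going by the values given here, the group that enters is the one also found in compound 3, but compound 3 carries it on another core, so no step between measured compounds speaks to this change on the core of compound 1. The expectation for compound 4 in this assay is therefore a small gain at most, in the direction of compound 3, with a fair chance of no effect beyond the scatter. Compound 4 is estimated at 20%, with a range from 0% to 55%.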

Compound 4, a percentage reported as activity, at one concentration (the size of the read-out at that concentration, not a potency): 44.4%
Compound 4: the middle estimate sits 24.4 percentage points below what was measured, and the stated range covers the measured number.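

Compound 1 at "not active" (no number reported) carries no number and compound 4 stands at 44.4%, so no step can be read between them. The compounds shown leave open how large the sulfur-to-oxygen change is on this core. No measurement at hand speaks to an explanation.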